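A few compounds are considered here, and "the series" means these few. Any claim that something is new, unique, unknown or untested is made for them only; others in the source may bear on it.

In a functional assay on THP-1 cells (Homo sapiens) for inhibition, read by sulforhodamine B assay, with a stated time of 48 h, tested at 50 uM (a lower number here means less inhibition of growth, a higher number more inhibition of growth at the concentration tested), two compounds have been measured so far. Compound 1 `COc1cc(/C=C/C(=O)/C=C/c2cccs2)ccc1OCc1cn(CCOc2cc(=O)oc3ccccc23)nn1` gives 76%, and compound 2 `COc1cccc(/C=C/C(=O)/C=C/c2ccc(OCc3cn(CCOc4cc(=O)oc5ccccc45)nn3)c(OC)c2)c1` gives 77%. These values lie within the scatter of each other, so compound 2 stands level with compound 1, and neither can be called the better of the pair.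

The next molecule, compound 3 `COc1cc(/C=C/C(=O)/C=C/c2cc(OC)c(OC)c(OC)c2)ccc1OCc1cn(CCOc2cc(=O)oc3ccccc23)nn1`, differs from compound 2 in one group: 3,4,5-trimethoxyphenyl in place of 3-methoxyphenyl on a double-bonded chain carbon bound to a double-bonded chain carbon. Put simply, 3,4,5-trimethoxyphenyl sits in place of 3-methoxyphenyl on a double-bonded chain carbon bound to a double-bonded chain carbon.

Among the compounds with values here, only one measured step bears on this change, as it concerns the same place. Putting 3-methoxyphenyl in place of thiophen-2-yl gave a number 1 percentage points higher from compound 1 to compound 2 (within the scatter). Within the data shown here, this single small step is thin evidence, and no measured compound carries the 3,4,5-trimethoxyphenyl group. Even so, with a number 1 percentage points higher from compound 1 to compound 2 (within the scatter) as the only guide, no shift beyond the scatter is expected in this assay. The estimated change is a number 1 percentage points higher from compound 2 to compound 3 (within the scatter). For compound 3, the estimated value is 78%, with an expected range from 64% to 90%.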

Compound 3, percent growth inhibition at one concentration: 99%
Estimate against measurement, compound 3: 21 percentage points below, and the stated range ends below it.
By their numbers in this assay, from the lowest: compounds 1 and 2 (each within the scatter of the next); then compound 3.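

At this position, on a double-bonded chain carbon bound to a double-bonded chain carbon, the group is not interchangeable after all: in this assay, replacing thiophen-2-yl with 3-methoxyphenyl gave only a number 1 percentage points higher from compound 1 to compound 2 (within the scatter), whereas 3,4,5-trimethoxyphenyl gives a number 22 percentage points higher from compound 2 to compound 3 (beyond the scatter) and a number 23 percentage points higher from compound 1 to compound 3 (beyond the scatter). Set against 3-methoxyphenyl, the new group keeps the same six-membered aromatic ring of carbon only but has 12 heavy atoms rather than 8 and 3 hydrogen-bond acceptors rather than 1, so the step changes both size and acceptor count at once. No measurement available here explains the rise or separates these two differences.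

Going by these compounds, it remains open whether all the methoxy groups of 3,4,5-trimethoxyphenyl are needed, and what a phenyl ring carrying a dimethylamino group or a carboxylic acid would give at this place. With compound 3 at 99% in a test at a single concentration, it is also unclear how much stronger compound 3 would prove across a range of concentrations.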